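Swapping quinolin-8-yl for naphthalen-1-yl in compound 1

The compounds below may be only part of what the source reports. "The series", "measured", "known", "first", "only" and "open" are said of these compounds alone.

Compound 1 `Cn1cncc1C(OCc1ccc(C#N)cc1)c1ccc(C#N)c(-c2cccc3cccnc23)c1`: 3.7 nM
Compound 2 `Cn1cncc1C(OCc1nc(N2CCC(O)CC2)c(C#N)cc1-c1cccc(Cl)c1)c1ccc(C#N)cc1`: 3.6 nM

In a functional assay on NIH3T3 cells (Mus musculus) (a lower number here means that less compound is needed, a higher number that more compound is needed for the effect), compound 1 gives 3.7 nM and compound 2 gives 3.6 nM. These two numbers lie within the usual scatter of each other, so compound 1 stands level with compound 2 on the evidence so far. Among the measured compounds shown here, no two measured compounds differ in only one place, so the data contain no measured step to serve as a guide.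

Compound 3 `Cn1cncc1C(OCc1ccc(C#N)cc1)c1ccc(C#N)c(-c2cccc3ccccc23)c1` keeps the rest of compound 1 and changes a single group: naphthalen-1-yl in place of quinolin-8-yl on an aromatic carbon. Naphthalen-1-yl takes the place of quinolin-8-yl on an aromatic carbon, ortho to a cyano group. The data do not show how this swap affects the number. The expectation in this assay is therefore no step beyond the scatter, with at most a slight drift toward a higher number. The expected size is a 1.4-fold higher number from compound 1 to compound 3 (0.13 log units; within the scatter). For compound 3, the estimated value is 5 nM, with an expected range from 1.5 nM to 18 nM.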

Compound 3, half-maximal effective concentration: 110 nM
Compound 3: the middle estimate sits 22-fold (1.34 log units) below what was measured, outside the stated range (above it).
By their numbers in this assay, from the lowest: compounds 2 and 1 (each within the scatter of the next); then compound 3.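

In this assay, putting naphthalen-1-yl in place of quinolin-8-yl on the aromatic carbon ortho to a cyano group gives a 30-fold higher number from compound 1 to compound 3 (1.47 log units; beyond the scatter), well beyond the scatter, so far more compound is needed for the same effect. The two groups have the same number of heavy atoms and both consist of two fused six-membered aromatic rings, yet quinolin-8-yl holds one ring nitrogen, counted as a hydrogen-bond acceptor, where naphthalen-1-yl has only carbon, so this position responds strongly to a change of a single ring atom. No measurement of any other property bears on this step, and the reason for it stays unknown.

Going by these compounds, it remains open whether a smaller single-ring group such as pyridin-3-yl, or a plain phenyl group, would keep the value of compound 1 or fall closer to that of compound 3. On these data alone, it is also open whether the same swap would have a step of similar size on a different core, since compound 2 differs from compound 1 in more than one place and cannot answer this.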